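Butyl chain replacement on the shared core

This account rests on a few compounds, and the source may have more. Where it says the series, first, only, none or still open, it means among the compounds named here.

Measured so far:
Compound 1 `CN1CCN(CCn2c(N)c(-c3nc4ccccc4[nH]3)c3nc(C#N)c(C#N)nc32)CC1` — 4300 nM
Compound 2 `CCCCn1c(N)c(-c2nc3ccccc3[nH]2)c2nc(C#N)c(C#N)nc21` — > 50000 nM

Compound 1 gives 4300 nM in a functional assay on HL-60 cells (Homo sapiens) for antiproliferative activity, read by MTT assay, with a stated time of 48 h; on this read-out lower numbers stand for stronger inhibition and higher numbers for weaker inhibition. For compound 2 this assay returns only a limit, > 50000 nM, not a number; this is the limit of > 50000 nM in this assay, at which 1 of the 2 values shown sits. Going by the values given here, the one step seen so far, an at least 11-fold higher number from compound 1 to compound 2 (1.06 log units; beyond the scatter), replaces a chain-terminal amine-bearing ring with a plain alkyl end and costs a large amount. The next compound, compound 3 `N#Cc1nc2c(-c3nc4ccccc4[nH]3)c(N)n(CCCNc3ccccc3)c2nc1C#N`, returns a nitrogen to the chain end: anilino in place of methyl on a saturated chain carbon, three bonds along the chain from an aromatic nitrogen. Among the compounds with values here, only the step from compound 1 to compound 2 bears on this change, and it ran in the opposite direction, so some recovery from the limit of compound 2 is expected rather than further loss; how much remains uncertain because the anilino group differs from the group lost in compound 1. Compound 3 is therefore expected at 20000 nM (range 5000 nM to 80000 nM), which means an expected step of an at least 2.5-fold lower number from compound 2 to compound 3 (0.39 log units; beyond the scatter).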

Compound 3, half-maximal inhibitory concentration: 6920 nM
Beside the measured number, compound 3's estimate is 2.9-fold (0.46 log units) above it, within the range that was stated.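

In this assay, replacing butyl with 3-anilinopropyl on the shared core gives an at least 7.2-fold lower number from compound 2 to compound 3 (0.85 log units; beyond the scatter), so the chain position does not need the 4-methylpiperazin-1-yl group to read below the limit. The change from the 4-methylpiperazin-1-yl chain to the 3-anilinopropyl chain gives a 1.6-fold higher number from compound 1 to compound 3 (0.21 log units; within the scatter), so these two nitrogen-bearing chain ends cannot be told apart here. Compound 2 gives only a limit, so the first step has a lower bound on its size and no exact size: the limit of > 50000 nM in this assay, at which 1 of the 3 values shown sits.

The anilino group adds both a nitrogen and an aromatic ring, and the compounds shown do not separate the two. A 3-phenylpropyl chain would test the ring without the nitrogen, and a 3-aminopropyl chain would test the nitrogen without the ring.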